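Allyl thiourea in place of tert-butyl isothiourea on the shared core

A few compounds are considered here, and "the series" means these few. Any claim that something is new, unique, unknown or untested is made for them only; others in the source may bear on it.

Measured compounds:
compound 1, `CC(C)(C)/N=C(\S)NCCCCn1nc(-c2ccccc2)ccc1=O`, 33.6%
compound 2, `CC/N=C(/NC#N)NCCCCn1nc(-c2ccccc2)cc(C)c1=O`, 42.5%
compound 3, `C/N=C(/NC#N)NCCCCn1nc(-c2ccc(Cl)cc2)ccc1=O`, 51%

Of the compounds shown here, three have been tested in a functional assay on the whole organism with Rattus norvegicus as the target, at a dose of 100 mg/kg; on this read-out lower numbers stand for less inhibition and higher numbers for more inhibition at the one dose given (going by the name of the read-out). Compound 1 gives 33.6%. The number of compound 2, 42.5%, lies within the usual scatter of that of compound 1, so nothing separates the two. The number of compound 3, 51%, lies beyond the scatter above compound 1, and it is the only one of the three that does.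

Compound 4, `C=CCNC(=S)NCCCCn1nc(-c2ccccc2)ccc1=O`, has not been measured in this assay. It differs from compound 1 in one place: a group of 6 heavy atoms (4 carbon, 1 nitrogen, 1 sulfur; no ring) in place of a group of 7 heavy atoms (5 carbon, 1 nitrogen, 1 sulfur; no ring), on an amine nitrogen. No pair of measured compounds differs in one place, so no step of this kind has been seen, and the three measured numbers give no reason to expect a move beyond the scatter in either direction.

The step expected from compound 1 to compound 4 is a number 4.4 percentage points higher from compound 1 to compound 4 (within the scatter), small and not beyond the scatter. For compound 4 in this assay the estimate is 38%, with a range from 20% to 58%.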

Compound 4, a percentage reported as inhibition, in the whole organism at one dose (the size of the read-out at that dose, not a potency): 27.1%
Compound 4: middle estimate off by 10.9 percentage points, on the high side; the range from low to high includes it.
By their numbers in this assay, from the lowest: compounds 4, 1, 2 and 3 (each within the scatter of the next, the first and the last beyond it).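

In this assay, the first step read at this amine nitrogen is a number 6.5 percentage points lower from compound 1 to compound 4 (within the scatter), so this exchange of allyl thiourea for tert-butyl isothiourea does not separate the two compounds. The change is a narrow one, as both groups carry one nitrogen and one sulfur and neither has a ring, so the result speaks only for this small exchange on the shared core and not for the position as a whole. Nothing in the available data bears on what lies behind this result.

As far as these compounds go, whether the number at this nitrogen can move beyond the scatter remains open, since a group with a ring, such as benzyl, or a urea with oxygen in place of sulfur, does not appear here. Nor do the compounds shown say how a shorter chain than the butyl linker would read on this core.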